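The compounds below may be only part of what the source reports. "The series", "measured", "known", "first", "only" and "open" are said of these compounds alone.

Measured so far:
- compound 1, `CC(C(=O)NCc1ccc(C(F)(F)F)nc1Nc1ccccc1)c1ccc(NS(C)(=O)=O)c(F)c1`: 59.6 nM in a functional assay on CHO-K1 cells for antagonist activity at transient receptor potential cation channel subfamily V member 1 (Homo sapiens), read by FLIPR; on this read-out lower numbers stand for stronger inhibition and higher numbers for weaker inhibition
- compound 2, `COC1CCN(c2nc(C(F)(F)F)ccc2CNC(=O)C(C)c2ccc(NS(C)(=O)=O)c(F)c2)CC1`: 2.4 nM in this assay

For the measured compounds named here, on these two numbers compound 2 stands lowest; its nearest neighbour is compound 1, the one step recorded being a 25-fold lower number from compound 1 to compound 2 (1.40 log units; beyond the scatter). Compound 3, `CC(C(=O)NCc1ccc(C(F)(F)F)nc1N1CCN(C2CCCCC2)CC1)c1ccc(NS(C)(=O)=O)c(F)c1`, carries the change (4-cyclohexylpiperazin-1-yl in place of 4-methoxypiperidin-1-yl on an aromatic carbon). Going by the values given here, the single measured step exchanged anilino for a saturated ring joined through nitrogen; the step to compound 3 exchanges one such ring for another of the same kind, so no measured step covers this exchange directly and the large step from compound 1 to compound 2 serves only as a sign that this position tolerates a saturated ring joined through nitrogen. In this assay no step beyond the scatter is therefore expected, and the estimate is a 1.3-fold higher number from compound 2 to compound 3 (0.10 log units; within the scatter). For compound 3 the expected value is 3 nM, with a range from 0.8 nM to 12 nM.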

Compound 3, inhibition constant: 21.6 nM
Compound 3: the middle estimate sits 7.2-fold (0.86 log units) below what was measured, and the stated range ends below it.
By their numbers in this assay, from the lowest: compound 2; then compound 3; then compound 1.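

In this assay, saturated rings joined through nitrogen are not interchangeable on this aromatic carbon next to the ring nitrogen: 4-cyclohexylpiperazin-1-yl in place of 4-methoxypiperidin-1-yl gives a 9.0-fold higher number from compound 2 to compound 3 (0.95 log units; beyond the scatter). The same group in place of anilino gives a 2.8-fold lower number from compound 1 to compound 3 (0.44 log units; beyond the scatter), so it keeps a modest gain over anilino but does not match the larger gain seen with 4-methoxypiperidin-1-yl. No measurement is at hand that bears on the reason for either step.

The change from 4-methoxypiperidin-1-yl to 4-cyclohexylpiperazin-1-yl alters several features at once, and the compounds shown do not separate the effect of the second ring nitrogen from that of the cyclohexyl ring. A 4-methylpiperazin-1-yl or a 4-cyclohexylpiperidin-1-yl group on the same carbon would divide this step into its parts.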